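This account rests on a few compounds, and the source may have more. Where it says the series, first, only, none or still open, it means among the compounds named here.

Working notes on the series. Among the measured compounds shown here, compound 3 `O=C(Nc1cccn2ccnc12)N1CCN(Cc2cccc(Oc3ccc(Cl)cc3)c2)CC1` gives 3500 nM in an assay on isolated protein for inhibition of Fatty-acid amide hydrolase 1 (Rattus norvegicus), with a stated time of 60 min (on this read-out lower numbers stand for stronger inhibition and higher numbers for weaker inhibition), the highest of the three numbers so far. Compound 1 `Cc1nc2cc(NC(=O)N3CCN(Cc4cccc(Oc5ccc(Cl)cc5)c4)CC3)ccc2o1` gives 200 nM and compound 2 `O=C(Nc1noc2cccnc12)N1CCN(Cc2cccc(Oc3ccc(Cl)cc3)c2)CC1` gives 22 nM in this assay; the steps of an 18-fold higher number from compound 1 to compound 3 (1.24 log units; beyond the scatter) and a 160-fold higher number from compound 2 to compound 3 (2.20 log units; beyond the scatter) both run upward, beyond the scatter, while a 9.1-fold lower number from compound 1 to compound 2 (0.96 log units; beyond the scatter) runs the other way. All three measured steps exchange one fused bicyclic group on the amide-type nitrogen for another and each moves the number well beyond the scatter, so this position is where the series is most sensitive.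

Compound 4 `O=C(Nc1ccc2nccn2c1)N1CCN(Cc2cccc(Oc3ccc(Cl)cc3)c2)CC1` is not yet measured. It differs from compound 3 in that (a group of 9 heavy atoms (7 carbon, 2 nitrogen; one five-membered aromatic ring with 2 hetero atoms, one six-membered aromatic ring with 1 hetero atom) in place of a group of 9 heavy atoms (7 carbon, 2 nitrogen; one five-membered aromatic ring with 2 hetero atoms, one six-membered aromatic ring with 1 hetero atom), on an amide-type nitrogen); the two have the same atoms, joined differently. For the measured compounds named here, no measured step is of this kind, so the direction rests only on the observation that changing this group has always moved the number by a large amount. A downward step is expected, a 5.8-fold lower number from compound 3 to compound 4 (0.77 log units; beyond the scatter), with wide uncertainty. Compound 4 is estimated at 600 nM, within a range from 100 nM to 4000 nM.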

Compound 4, half-maximal inhibitory concentration: 3600 nM
Beside the measured number, compound 4's estimate is 6.0-fold (0.78 log units) below it; the range from low to high includes it.
By their numbers in this assay, from the lowest: compound 2; then compound 1; then compounds 3 and 4 (each within the scatter of the next).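

Joining the same atoms differently in the group on the amide-type nitrogen gives a 1.0-fold higher number from compound 3 to compound 4 (0.01 log units; within the scatter), the first exchange at this position that stays within the scatter, so this position is not sensitive to every change of fused bicyclic group. Among the compounds shown here, the other two gaps remain wide (a 160-fold higher number from compound 2 to compound 4 (2.21 log units; beyond the scatter); an 18-fold higher number from compound 1 to compound 4 (1.26 log units; beyond the scatter)), and across these four compounds the two groups without oxygen among their atoms stand apart from the two that carry it, with no compound going against this split. No data are at hand that explain this split.

Open, on these data alone, is whether a group with no fused ring, such as a plain phenyl or pyridine, on the amide-type nitrogen would fall with compound 2 or with compound 4. Also open, as far as these compounds go, is whether an amine or a carboxylic acid on the fused group would alter the split.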